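The source may report more compounds than this note shows. Statements on the series, on what has been measured and on what is new or still open speak of the compounds shown alone.

Measured compounds:
- compound 1, `Cn1nc(-c2ccc(S(C)(=O)=O)cc2)s/c1=N\C1CCCC(O)C1`: 0.92 L/kg; 0.62 L/kg (2 entries)
- compound 2, `Cn1nc(-c2ccc(C(=O)NC(C)(C)CO)cc2)s/c1=N\C1CCCC(O)C1`: 0.43 L/kg
- compound 3, `Cn1nc(-c2ccc(C(N)=O)cc2)s/c1=N\C1CCCC(O)C1`: 1.39 L/kg; 1.78 L/kg (2 entries)

In an in vivo ADME assay on the whole organism for pharmacokinetics, at a dose of 0.5 mg/kg by the intravenous route (on this read-out higher numbers stand for wider distribution into tissues and lower numbers for narrower distribution), compound 2 gives 0.43 L/kg, and this is its only number; compounds 1 and 3 each have several entries, as shown by the several entries of compound 1 in this assay, 0.92 L/kg; 0.62 L/kg (2 entries) and (the several entries of compound 3 in this assay, 1.39 L/kg; 1.78 L/kg (2 entries)). Within the three, compound 2 carries the lowest single value shown, with compound 1 and compound 3 giving higher numbers on their repeated entries; no step between them has been computed, so only the bare values are set side by side here.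

Compound 4, `CC(=O)Nc1ccc(-c2nn(C)/c(=N/C3CCCC(O)C3)s2)cc1`, has not been measured in this assay. It differs from compound 2 as follows: acetamido in place of (1-(hydroxymethyl)-1-methylethyl)carbamoyl on an aromatic carbon. The group that leaves is the larger one, carrying the hydroxymethyl, and the acetamido that enters is smaller. A modest step upward in this assay is expected, a 1.9-fold higher number from compound 2 to compound 4 (0.27 log units; within the scatter), about the size of the usual scatter rather than clearly beyond it. Compound 4 is thus estimated at 0.8 L/kg, with a range from 0.4 L/kg to 1.6 L/kg.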

Compound 4, volume of distribution in the ADME assay: 2.02 L/kg
The estimate for compound 4 lay 2.5-fold (0.40 log units) below the measured number; the whole stated range lies below it.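

For the compounds shown here, in the ADME assay the exchange of (1-(hydroxymethyl)-1-methylethyl)carbamoyl for acetamido on this aromatic carbon gives a 4.7-fold higher number from compound 2 to compound 4 (0.67 log units; beyond the scatter) as the first computed step, so a change at this position can move the read-out past the usual scatter. In a physicochemical assay for solubility, at pH 7.4 (on this read-out higher numbers stand for higher solubility and lower numbers for lower solubility), compound 2 gives 58 ug/mL and compound 4 gives 350 ug/mL with the same change, so both read-outs move the same way across this pair. The entering group is the smaller one, with fewer heavy atoms, hydrogen-bond donors and hydrogen-bond acceptors.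

This single pair cannot separate the loss of the hydroxymethyl from the change in size or from the different attachment of the amide. As far as these compounds go, how an amine or a carboxylic acid on this aromatic carbon would behave in either read-out remains open.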